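Removing one chloro from the core of compound 2

The source may report more compounds than this note shows. Statements on the series, on what has been measured and on what is new or still open speak of the compounds shown alone.

Of the compounds shown here, two have been measured in a functional assay on SN12C cells (Homo sapiens) for cytotoxicity, read by sulforhodamine B assay, with a stated time of 48 h; a lower number here means a stronger inhibitor of growth, a higher number a weaker inhibitor of growth. Compound 1 `ClCc1ccc(Cn2cnc3c(Cl)ncnc32)cc1` gives 2340 nM. Compound 2 `ClCc1ccccc1Cn1cnc2c(Cl)nc(Cl)nc21` gives 2040 nM, the lowest of the two numbers, though its nearest neighbour, compound 1, lies within the scatter of it, so the two cannot be ordered. Compound 3 `ClCc1ccccc1Cn1cnc2c(Cl)ncnc21` has not yet been measured in this assay. It differs from compound 2 in one place: hydrogen in place of chloro on an aromatic carbon. Among the measured compounds shown here, no pair of measured compounds shows this exact change, so the size of the step is open. Since compound 1, which also carries a single chloro on the core, gives 2340 nM, the step from compound 2 to compound 3 is expected to stay within the scatter, a 1.2-fold higher number from compound 2 to compound 3 (0.07 log units; within the scatter). Compound 3 is therefore estimated to give 2400 nM, with a range from 1000 nM to 5500 nM.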

Compound 3, concentration for total growth inhibition: 8710 nM
For compound 3 the middle estimate is 3.6-fold (0.56 log units) below the measured one; measured number outside the range, above it.
By their numbers in this assay, from the lowest: compounds 2 and 1 (each within the scatter of the next); then compound 3.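

In this assay the chloro on the aromatic carbon between two ring nitrogen atoms proves to matter: hydrogen in its place gives a 4.3-fold higher number from compound 2 to compound 3 (0.63 log units; beyond the scatter) and so a weaker inhibitor of growth. Among the compounds shown here, this is the first step read at this position, and it is modest but lies beyond the scatter, so within this pair the second chloro on the core goes with stronger growth inhibition. Nothing given here accounts for the size of this step.

The compounds shown leave open whether the gain belongs to chloro itself or whether another group at this carbon, such as an amine, a methoxy group or fluoro, would serve equally well or better. They also leave open whether the same change would give a step of similar size with the chloromethyl group placed elsewhere on the benzyl ring.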